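This account rests on a few compounds, and the source may have more. Where it says the series, first, only, none or still open, it means among the compounds named here.

Measured compounds:
compound 1 `CCOc1ccc(-n2nncc2CN2C(=O)C3(C(C#N)=C(N)Oc4c3c3nc5ccccc5nc3c3ccccc43)c3ccccc32)cc1`, in a functional assay on A549 cells (Homo sapiens) for antiproliferative activity, read by MTT assay, with a stated time of 48 h (on this read-out lower numbers stand for stronger inhibition and higher numbers for weaker inhibition), compound 1 gives 25200 nM
compound 2 `N#CC1=C(N)Oc2c(c3nc4ccccc4nc3c3ccccc23)C12C(=O)N(Cc1cnnn1-c1cccc(S(N)(=O)=O)c1)c1ccccc12`, in this assay compound 2 gives 44200 nM

Compound 2 stands highest of the two numbers shown, but its only neighbour is compound 1, and the step of a 1.8-fold higher number from compound 1 to compound 2 (0.24 log units; within the scatter) lies within the scatter, so the two are not separated. Compound 3 `Cc1cc(C)cc(-n2nncc2CN2C(=O)C3(C(C#N)=C(N)Oc4c3c3nc5ccccc5nc3c3ccccc43)c3ccccc32)c1` is not yet measured. It differs from compound 2 at one place: 3,5-dimethylphenyl in place of 3-sulfamoylphenyl on an aromatic nitrogen. Among the measured compounds shown here, the one measured step that bears on this position is the exchange of 4-ethoxyphenyl for 3-sulfamoylphenyl on the same aromatic nitrogen, a 1.8-fold higher number from compound 1 to compound 2 (0.24 log units; within the scatter), which did not reach beyond the scatter. Compound 3 again carries a group with no hydrogen-bond donor or acceptor, as compound 1 does, so only a small step, if any, is expected in this assay. The estimate is that compound 3 moves a 1.8-fold lower number from compound 2 to compound 3 (0.25 log units; within the scatter), towards the number of compound 1, with an expected value of 25000 nM in a range from 8000 nM to 70000 nM.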

Compound 3, half-maximal inhibitory concentration: > 50000 nM
Compound 3: only a limit was reported (the forecaster's own chance of this, stated with the estimate: 5%); at least 2.0-fold (0.30 log units) between middle value and limit.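

In this assay compound 3 gives only a limit of the assay, > 50000 nM, and not a number. That limit fixes the new steps as floors only: an at least 1.1-fold higher number from compound 2 to compound 3 (0.05 log units; that floor lies within the scatter), and an at least 1.9-fold higher number from compound 1 to compound 3 (0.29 log units; that floor lies within the scatter). The 3,5-dimethylphenyl group on this aromatic nitrogen therefore gives no sign of a lower number, so a phenyl group with no hydrogen-bond donor or acceptor did not by itself bring a gain over 3-sulfamoylphenyl, and the series now touches the top of its range once: the limit of > 50000 nM in this assay, at which 1 of the 3 values shown sits.

On these data alone, how far the number of compound 3 lies beyond the limit stays open, so its order relative to compound 1 and compound 2 remains unsettled. Also open, as far as these compounds go, is whether an aminophenyl group, a benzoic acid or a longer alkyl chain on this nitrogen would give a clearly lower number.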